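Swapping 4-fluorobenzyl for 3-methoxybenzyl on a shared core

This account rests on a few compounds, and the source may have more. Where it says the series, first, only, none or still open, it means among the compounds named here.

Three compounds sharing one core were taken into a functional assay on cells (Hepatocyte, Rattus norvegicus) for inhibition, read by scintillation counting, with a stated time of 4 h; a lower number here means a stronger inhibitor, a higher number a weaker inhibitor. For compound 1 `O=C(O)C[C@H](O)C[C@H](O)CCn1c(-c2ccc(F)cc2)nc(C(=O)NCc2ccccc2F)c1C1CC1` the entry reads "not determined" (no result reported). Compound 2 `Cc1ccc(CNC(=O)c2nc(-c3ccc(F)cc3)n(CC[C@@H](O)C[C@@H](O)CC(=O)O)c2C2CC2)cc1` gives 0.1 nM, and compound 3 `O=C(O)C[C@H](O)C[C@H](O)CCn1c(-c2ccc(F)cc2)nc(C(=O)NCc2ccc(F)cc2)c1C1CC1` gives 0.7 nM, the higher of the two numbers. Compound 4 `COc1cccc(CNC(=O)c2nc(-c3ccc(F)cc3)n(CC[C@@H](O)C[C@@H](O)CC(=O)O)c2C2CC2)c1` awaits measurement. It differs from compound 3 as follows: 3-methoxyphenyl in place of 4-fluorophenyl on a saturated chain carbon bound to an amide-type nitrogen. For the measured compounds named here, the only measured step, a 7.0-fold higher number from compound 2 to compound 3 (0.85 log units; beyond the scatter), is modest, lies beyond the scatter and changes the same benzyl group, though it involves no methoxy group. A modest step toward a lower number is therefore expected, tentatively. The expected change is a 2.3-fold lower number from compound 3 to compound 4 (0.37 log units; beyond the scatter). The estimate for compound 4 is 0.3 nM, expected between 0.08 nM and 1.2 nM.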

Compound 4, half-maximal inhibitory concentration: 0.2 nM
Beside the measured number, compound 4's estimate is 1.5-fold (0.18 log units) above it; the measured number falls inside the stated range.
By their numbers in this assay, from the lowest: compounds 2 and 4 (each within the scatter of the next); then compound 3.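

In this assay, for the compounds shown here, the change from 4-fluorobenzyl to 3-methoxybenzyl on the amide nitrogen gives a 3.5-fold lower number from compound 3 to compound 4 (0.54 log units; beyond the scatter), showing that a methoxy group, absent from the earlier compounds, is accepted on this benzyl group with no loss. Set against 4-methylphenyl, 3-methoxyphenyl gives a 2.0-fold higher number from compound 2 to compound 4 (0.30 log units; within the scatter), so these two groups cannot be put in order here. Nothing accompanying these numbers explains the step.

Still open, from the compounds shown here alone, is whether 4-methoxybenzyl would read like 3-methoxybenzyl. Also open, going by these compounds, is how an amine or a hydroxyl group on the benzyl ring would compare.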